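Working notes: from compound 2 to compound 3

The compounds below may be only part of what the source reports. "The series", "measured", "known", "first", "only" and "open" are said of these compounds alone.

- compound 1 `C[N+]1(CC2CCC2)CCc2c(sc(NC(=O)Nc3ccc(Cl)cc3)c2C(N)=O)C1`: 210 nM
- compound 2 `CC(C)C[N+]1(C)CCc2c(sc(NC(=O)Nc3ccc(Cl)cc3)c2C(N)=O)C1`: 380 nM
- compound 3 `COCCC[N+]1(C)CCc2c(sc(NC(=O)Nc3ccc(Cl)cc3)c2C(N)=O)C1`: not yet measured

In a functional assay (strain AB) with Danio rerio as the target, read by microscopy, with a stated time of 1 h (a higher number here means that more compound is needed for the effect, a lower number that less compound is needed), compound 2 stands at 380 nM, within the scatter of compound 1, with a 1.8-fold higher number from compound 1 to compound 2 (0.26 log units; within the scatter). The next change is 2-methoxyethyl in place of isopropyl on a saturated chain carbon bound to an amine nitrogen in a ring. Among the compounds with values here, only that one step bears on it, and no measured compound carries 2-methoxyethyl. No step beyond the scatter is expected in this assay, and the expected step is a 1.3-fold higher number from compound 2 to compound 3 (0.12 log units; within the scatter). For compound 3 the estimate is 500 nM, with an expected range of 170 nM to 1500 nM.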

Compound 3, half-maximal effective concentration: 480 nM
Beside the measured number, compound 3's estimate is 1.0-fold (0.02 log units) above it; the measured number falls inside the stated range.
By their numbers in this assay, from the lowest: compounds 1, 2 and 3 (each within the scatter of the next, the first and the last beyond it).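

In this assay, 2-methoxyethyl, which brings a hydrogen-bond acceptor to this saturated chain carbon bound to an amine nitrogen in a ring, in place of isopropyl gives a 1.3-fold higher number from compound 2 to compound 3 (0.10 log units; within the scatter), so this change shows no clear separation from isopropyl. Against cyclobutyl, the same group gives a 2.3-fold higher number from compound 1 to compound 3 (0.36 log units; beyond the scatter), the first step at this position beyond the scatter, though a modest one. No measured evidence accounts for either step. Still open, as far as these compounds go, is how a longer chain, or a chain ending in an amine or a carboxylic acid, would read at this position in this assay.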